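A second trifluoromethyl on the urea aryl of compound 1

A few compounds are considered here, and "the series" means these few. Any claim that something is new, unique, unknown or untested is made for them only; others in the source may bear on it.

Compound 1 `O=C(Nc1cccc(-n2cc(-c3ccncc3)c(-c3ccc(Cl)c(O)c3)n2)c1)Nc1cccc(C(F)(F)F)c1` was examined in a functional assay on A498 cells (Homo sapiens) for inhibition, read by sulforhodamine B assay, with a stated time of 48 h; a higher number here means that more compound is tolerated, a lower number that less compound is tolerated. In this assay compound 1 gives > 32500 nM, which is a limit of the assay and not a number. Compound 2 `O=C(Nc1cccc(-n2cc(-c3ccncc3)c(-c3ccc(Cl)c(O)c3)n2)c1)Nc1ccc(Cl)c(Cl)c1` likewise reaches only the limit > 32500 nM in this assay. Compound 3 `COc1cc(-c2nn(-c3cccc(NC(=O)c4ccc(Cl)c(C(F)(F)F)c4)c3)cc2-c2ccncc2)ccc1Cl` also stops at the limit > 32500 nM in this assay. The step that the two limits leave unreadable from compound 1 to compound 2 therefore cannot be read. Compound 4 `O=C(Nc1cccc(-n2cc(-c3ccncc3)c(-c3ccc(Cl)c(O)c3)n2)c1)Nc1cc(C(F)(F)F)cc(C(F)(F)F)c1` differs from compound 1 by trifluoromethyl in place of hydrogen on an aromatic carbon. Among the measured compounds shown here, no measured step bears directly on this change, and all three measured values sit at the limit (the limit of > 32500 nM in this assay, at which 3 of the 3 values shown sit), so no step beyond the scatter can be anticipated. Compound 4 is therefore expected to give 45000 nM, between 20000 nM and 120000 nM, with the step that the limit leaves unreadable from compound 1 to compound 4 expected to remain unreadable in this assay.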

Compound 4, concentration lethal to 50% of the cells: 16000 nM
Compound 4: middle estimate off by 2.8-fold (0.45 log units), on the high side; the measured number lies below the stated range.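

In this assay, compound 4 is the only one of the compounds shown to give a number instead of a limit: the limit of > 32500 nM in this assay, at which 3 of the 4 values shown sit. Among the compounds shown here, at this aromatic carbon, meta to a trifluoromethyl group, trifluoromethyl in place of hydrogen gives the only step whose size can be read, an at least 2.0-fold lower number from compound 1 to compound 4 (0.30 log units; that floor lies within the scatter), and that size is a floor; the other step cannot be read. The compounds shown leave open whether a nitrile or an amine on this carbon would also give a number instead of a limit.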